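The source may hold more compounds than are shown below. What is called first, only, known or untested is meant among the compounds shown, and "the series" means these compounds.

Compound 2 `Cc1ccc(C(=O)Nc2ncc(C(Oc3ccc4cc(Br)ccc4c3)c3ccc(Cl)cc3)s2)cc1` belongs to a small set of compounds that share a core and were all tested in an ADME assay on HepG2 2.2.15 cells (Homo sapiens) for cytotoxicity; a lower number here means that less compound is tolerated, a higher number that more compound is tolerated. For compound 2 the result in this assay is recorded only as "not toxic" (no number reported), without a figure. Compound 1 `CC(C)(C)OC(=O)Nc1ncc(C(Oc2cccc(C#N)c2)c2ccc(Cl)cc2)s1` in this assay reaches only the limit of > 50000 nM, which is a boundary of the test rather than a measured number. Compound 3 `COc1ccc(C(=O)Nc2ncc(C(Nc3cccc4ccccc34)c3ccc(Cl)cc3)s2)cc1` likewise stops at the limit of > 50000 nM in this assay. So compound 2 stands among compounds that all sit at or beyond the tolerated edge, and the limit of the test is where most of the set rests (the limit of > 50000 nM in this assay, at which 2 of the 3 values shown sit).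

The step to compound 4 `O=S(=O)(Nc1ncc(C(Oc2ccc3cc(Br)ccc3c2)c2ccc(Cl)cc2)s1)c1ccc(Cl)cc1` replaces one group on the core: (4-chlorophenyl)sulfonyl in place of (4-methylphenyl)carbonyl on a nitrogen on an aromatic ring. Going by the values given here, no measured pair in this set shows the effect of such a swap, so no size of step can be drawn from the data; the expectation is a change in this assay not larger than the usual scatter, in no particular direction. For compound 4 the expected result in this assay is 50000 nM, with a likely range from 20000 nM to 100000 nM, most probably again reported only as a limit.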

Compound 4, half-maximal cytotoxic concentration: "not toxic" (no number reported)
Nothing numeric was reported for compound 4; no gap can be computed for the estimate.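

Compound 2 and compound 4 are both recorded in this assay only as "not toxic", without a figure, so no step can be read between them. The compounds shown leave open at what concentration any of them would harm these cells, and the numeric results stop at a limit: the limit of > 50000 nM in this assay, at which 2 of the 4 values shown sit.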